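The source may hold more compounds than are shown below. What is called first, only, known or untested is meant among the compounds shown, and "the series" means these compounds.

Measured compounds: compound 1 `CC(C)(O/N=C(\C(=O)N[C@@H]1C(=O)N(S(=O)(=O)O)[C@@H]1Cn1ccnn1)c1csc(N)n1)C(=O)O`; compound 2 `C[C@@H]1CN(C[C@@H]2[C@H](NC(=O)/C(=N\OC(C)(C)C(=O)O)c3csc(N)n3)C(=O)N2S(=O)(=O)O)C(=O)O1`.

Within the data shown here, in a physicochemical assay for metabolic stability, read by HPLC and mass spectrometry, in phosphate buffer, at 37 degrees C, at pH 7.4 (on this read-out lower numbers stand for a shorter-lived compound and higher numbers for a longer-lived compound), compound 1 gives 257 h, the only number in the set. For compound 2 the value > 37 h is a limit of the assay, not a number, as recorded in the limit of > 37 h in this assay, at which 1 of the 2 values shown sits. The step that the limit leaves unreadable from compound 1 to compound 2 is therefore unreadable in size. Compound 3 `CC(C)(O/N=C(\C(=O)N[C@@H]1C(=O)N(S(=O)(=O)O)[C@@H]1Cn1ncnc1CNC(=N)N)c1csc(N)n1)C(=O)O` differs from compound 1 by a group of 10 heavy atoms (4 carbon, 6 nitrogen; one five-membered aromatic ring with 3 hetero atoms) in place of a group of 5 heavy atoms (2 carbon, 3 nitrogen; one five-membered aromatic ring with 3 hetero atoms), on a saturated chain carbon bound to a saturated ring carbon. No readable measured step bears on this change, so nothing beyond the usual scatter is expected, and the estimate for compound 3 stays close to compound 1 with a wide range. Compound 3 is expected to give 200 h (range 70 h to 600 h), a step of a 1.3-fold lower number from compound 1 to compound 3 (0.11 log units; within the scatter).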

Compound 3, half-life: > 37 h
Compound 3: only a limit was reported (the forecaster's own chance of this, stated with the estimate: 30%); the middle value lies beyond the limit too.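

In this assay, among these compounds, compound 3 gives > 37 h, a limit and not a number, so no step from compound 1 or compound 2 to compound 3 can be read. How far the half-lives of compound 2 and compound 3 lie from that of compound 1 stays open: the limit of > 37 h in this assay, at which 2 of the 3 values shown sit.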